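Thiophene replaces methylfuran on a fused bicyclic core

A few compounds are considered here, and "the series" means these few. Any claim that something is new, unique, unknown or untested is made for them only; others in the source may bear on it.

The account follows two measured compounds and one not yet measured. Compound 1 `COc1cccc(CNc2nc(N)c3nc(-c4cccs4)sc3n2)c1` and compound 2 `COc1ccccc1CNc1nc(N)c2nc(-c3ccc(C)o3)sc2n1` share the same fused core and differ in the five-membered aromatic ring attached to it and in the placement of the methoxy group on the benzyl ring. In an assay on CHO cells for displacement of a labelled ligand from adenosine receptor A3 (Homo sapiens), read by scintillation counting, with a stated time of 120 min (a higher number here means a weaker inhibitor, a lower number a stronger inhibitor), compound 1 gives 430 nM, and compound 2 gives 141 nM. Compound 2 thus stands with the lower of the two numbers, and its gap to compound 1 lies beyond the usual scatter.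

Compound 3 `COc1ccccc1CNc1nc(N)c2nc(-c3cccs3)sc2n1` is built from compound 2 by one change: thiophen-2-yl in place of 5-methylfuran-2-yl on an aromatic carbon. For the measured compounds named here, no measured pair shows this exact exchange on its own. Going by the values given here, the only guide is that compound 1, which also carries thiophen-2-yl, gives 430 nM in this assay, although its methoxy group sits elsewhere. The estimated step is therefore a 1.6-fold higher number from compound 2 to compound 3 (0.19 log units; within the scatter), a small one toward a higher number that is not clearly beyond the scatter. Compound 3 is expected to give about 220 nM, within a range from 70 nM to 700 nM.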

Compound 3, inhibition constant: 275 nM
The estimate for compound 3 lay 1.3-fold (0.10 log units) below the measured number; low and high end bracket the measured number.
By their numbers in this assay, from the lowest: compounds 2, 3 and 1 (each within the scatter of the next, the first and the last beyond it).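

Compound 3 shares one structural difference with each earlier compound, so each exchange can now be read alone in this assay. Thiophen-2-yl in place of 5-methylfuran-2-yl on the aromatic carbon gives a 2.0-fold higher number from compound 2 to compound 3 (0.29 log units; within the scatter), while 2-methoxyphenyl in place of 3-methoxyphenyl gives a 1.6-fold lower number from compound 1 to compound 3 (0.19 log units; within the scatter), so neither single change reaches beyond the scatter. Nothing available here accounts for either step.

The exchange at the five-membered ring removes a methyl group and changes oxygen to sulfur together, so furan-2-yl and 5-methylthiophen-2-yl would be needed to read those two parts separately. Also open, going by these compounds, is how this assay would read with a primary amine or a carboxylic acid on the five-membered ring at this carbon, or with a hydroxyl group or a chlorine atom in place of the methoxy group on the benzyl ring.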